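A few compounds are considered here, and "the series" means these few. Any claim that something is new, unique, unknown or untested is made for them only; others in the source may bear on it.

Compound 1 `N#Cc1ccc(OCc2cn(C(c3ccc(C#N)cc3)c3ccc(C#N)cc3)nn2)cc1` gives 4640 nM in an assay on isolated protein for inhibition of Aromatase (Homo sapiens), read by fluorescence and colorimetric assay, with a stated time of 30 min; a lower number here means a stronger inhibitor, a higher number a weaker inhibitor. Compound 2 `COc1ccc(OCc2cn(C(c3ccc(C#N)cc3)c3ccc(C#N)cc3)nn2)cc1` gives 12200 nM. Compound 3 `CCCc1cn(C(c2ccccc2)c2ccccc2)nn1` gives 11000 nM.

Among these three, compound 3 gives a number that lies within the scatter of that of compound 2, while its number is higher than that of compound 1 and beyond the scatter of it. Compound 4 `c1ccc(C(c2ccccc2)n2cc(C3CCCCC3)nn2)cc1` differs from compound 3 in one place: cyclohexyl in place of propyl on an aromatic carbon. Within the data shown here, the only measured step, a 2.6-fold higher number from compound 1 to compound 2 (0.42 log units; beyond the scatter), concerns a group on a different ring and does not bear on this change. Among the measured compounds shown here, with no step of this kind measured, the change is expected to bring no shift beyond the scatter, so for compound 4 the expected step is a 1.2-fold lower number from compound 3 to compound 4 (0.09 log units; within the scatter). Compound 4 is estimated at 9000 nM, with a range from 3000 nM to 27000 nM.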

Compound 4, half-maximal inhibitory concentration: 13700 nM
For compound 4 the middle estimate is 1.5-fold (0.18 log units) below the measured one; the measured number falls inside the stated range.
By their numbers in this assay, from the lowest: compound 1; then compounds 3, 2 and 4 (each within the scatter of the next).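

Replacing propyl with cyclohexyl on this aromatic carbon gives a 1.2-fold higher number from compound 3 to compound 4 (0.10 log units; within the scatter) in this assay, so this first change measured at the position, from a chain to a carbon-only six-membered ring, leaves the number within the scatter. Within this pair, the position accepts either group without a measurable difference. No measurement available here accounts for this result.

Going by these compounds, whether an amine, a carboxylic acid or a longer chain at this position would move the number remains open. On these data alone, it is also open whether cyclohexyl would behave the same way on the nitrile-bearing core of compound 1.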